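The compounds below may be only part of what the source reports. "The series", "measured", "known", "first", "only" and "open" are said of these compounds alone.

Measured compounds, with their values in an assay on HEK293 cells for agonist activity at transient receptor potential cation channel subfamily M member 8 (Homo sapiens), read by fluorescence and calcium flux, with a stated time of 15 min; a higher number here means that more compound is needed for the effect, a lower number that less compound is needed:
- compound 1 `Cc1ccc(OCC(=O)N(Cc2cccs2)c2ccn(C)n2)cc1`: in this assay compound 1 gives 855 nM
- compound 2 `Cc1ccc(OCC(=O)N(Cc2cccs2)c2ccon2)cc1`: in this assay compound 2 gives 2 nM

For the measured compounds named here, compound 2 has the lowest number of the two in this assay; its nearest neighbour is compound 1, and the only step in the set, a 430-fold lower number from compound 1 to compound 2 (2.63 log units; beyond the scatter), is large and well beyond the scatter. That step swaps one five-membered aromatic ring for another on the amide-type nitrogen and says nothing directly about leaving aromatic rings altogether.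

Compound 3 `Cc1ccc(OCC(=O)N(Cc2cccs2)C2CC2)cc1` is not yet measured. It differs from compound 2 by cyclopropyl in place of 1,2-oxazol-3-yl on an amide-type nitrogen. Going by the values given here, no measured step replaces a five-membered aromatic ring on this nitrogen with a non-aromatic carbon ring, so the expectation rests on the single step available: the number at this position moved by a 430-fold lower number from compound 1 to compound 2 (2.63 log units; beyond the scatter) between two aromatic groups, so a change at the same site is likely to show again as a step beyond the scatter, and, compound 2 holding the lowest number, most plausibly towards a higher number. Compound 3 is therefore expected to give a higher number than compound 2 in this assay, an estimated step of a 200-fold higher number from compound 2 to compound 3 (2.30 log units; beyond the scatter). The estimate for compound 3 in this assay is 400 nM, with a range from 40 nM to 4000 nM.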

Compound 3, half-maximal effective concentration: 8 nM
For compound 3 the middle estimate is 50-fold (1.70 log units) above the measured one; measured number below the stated range.
By their numbers in this assay, from the lowest: compound 2; then compound 3; then compound 1.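

Cyclopropyl on the amide-type nitrogen shows that neither an aromatic ring nor a hetero atom in this group is needed for a low number in this assay: there is a 4.0-fold higher number from compound 2 to compound 3 (0.60 log units; beyond the scatter), which is modest though beyond the scatter, against a 110-fold lower number from compound 1 to compound 3 (2.03 log units; beyond the scatter), which is large. The position therefore accepts two quite different groups, a five-membered aromatic ring with 2 hydrogen-bond acceptors and a three-membered carbon ring with none, and of the three groups shown, 1-methyl-1H-pyrazol-3-yl is the one that stands far apart. No measurement on hand accounts for this order of the three groups.

The compounds shown leave open whether the high number of compound 1 goes with the methyl group on its ring, which 1H-pyrazol-3-yl would test, or with the pyrazole ring itself. They also leave open how far the tolerance for carbon groups extends at this nitrogen, from larger rings such as cyclobutyl and cyclopentyl to open chains such as isopropyl, or to a group carrying an amine.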